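A Methoxy Swap at the Limit of Cytotoxicity

The source may hold more compounds than are shown below. What is called first, only, known or untested is meant among the compounds shown, and "the series" means these compounds.

Two compounds sharing one core have been examined so far: compound 1 `CC1CCN(C2CCN(S(=O)(=O)c3ccc(Br)cc3OC(F)(F)F)CC2)CC1` and compound 2 `CC1CCN(C2CCN(S(=O)(=O)c3ccc(-c4ccc(Cl)cc4)cc3)CC2)CC1`. In an ADME assay on HCT-116 cells (Homo sapiens) for cytotoxicity, read by CellTiter-Glo, with a stated time of 72 h (a higher number here means a weaker inhibitor, a lower number a stronger inhibitor), compound 1 gives > 5000 nM, which is a limit of the assay and not a number. Compound 2 gives > 5000 nM, which is likewise only a limit. Compound 2 therefore has no numerical value, and the data show (the limit of > 5000 nM in this assay, at which 2 of the 2 values shown sit).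

Compound 3 `COc1ccc(-c2ccc(S(=O)(=O)N3CCC(N4CCC(C)CC4)CC3)cc2)cc1` departs from compound 2 at a single place: methoxy in place of chloro on an aromatic carbon. Methoxy stands in place of chloro on an aromatic carbon, para to a large group, so that 4-chlorophenyl becomes 4-methoxyphenyl. Among the compounds with values here, no measured pair of compounds shows what such a change does in this assay. Resting only on compound 2 at > 5000 nM, a limit, no shift beyond the usual scatter is expected. The estimated change, a step that the limit leaves unreadable from compound 2 to compound 3, is expected to stay within that scatter. The assay may well report only a limit again. As a number, compound 3 is expected at 7000 nM, with an estimated range of 3000 nM to 15000 nM.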

Compound 3, half-maximal inhibitory concentration: > 5000 nM
Compound 3 gave a limit, no number; the forecaster's own chance of this, stated with the estimate: 80%; the middle value does not contradict the limit.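

No step can be read between compound 2 and compound 3, since in this assay each stands only at a limit and not at a number: the limit of > 5000 nM in this assay, at which 3 of the 3 values shown sit.

The compounds shown leave open whether methoxy in place of chloro on an aromatic carbon alters cytotoxicity at all, and at what concentration any of the three would reach half-maximal inhibition.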